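The source may report more compounds than this note shows. Statements on the series, on what has been measured and on what is new or still open speak of the compounds shown alone.

Measured so far in a functional assay (Homo sapiens) for inhibition; a lower number here means a stronger inhibitor, a higher number a weaker inhibitor:
compound 1 `C=CCOc1ccc(C(=O)/C=C/c2cc(OC)cc(OC)c2)cc1` gives 25000 nM
compound 2 `COc1ccc(C(=O)/C=C/c2ccc(F)c(F)c2)c(OC)c1` gives 5300 nM
compound 3 `C=CCOc1ccc(C(=O)/C=C/c2cc(OC)ccc2OC)cc1` gives 55000 nM

Compound 3 has the highest number of the three and is the weakest inhibitor here, with its gaps to both compound 1 and compound 2 beyond the scatter. Compound 4 `COc1ccc(OC)c(/C=C/C(=O)c2ccc(O)cc2)c1` is still unmeasured. It differs from compound 3 by hydrogen in place of allyl on an oxygen on an aromatic ring, which is hydrogen in place of allyl on an oxygen on an aromatic ring, or allyloxy to hydroxy. Among the compounds with values here, no measured pair shows this change, so the expectation is only loosely supported. Compound 1 also carries the allyloxy group and gives 25000 nM as a number. Compound 2 lacks that group and gives 5300 nM as a number, but it differs elsewhere too. From the top of so small a set, a moderate move towards a lower number seems most likely. The expected change is a 2.5-fold lower number from compound 3 to compound 4 (0.40 log units; beyond the scatter) in this assay as a modest gain in inhibition. The estimate for compound 4 is 22000 nM, with an expected range from 7000 nM to 70000 nM.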

Compound 4, half-maximal inhibitory concentration: 22000 nM
Compound 4: middle estimate and measured number agree at the digits printed; low and high end bracket the measured number.
By their numbers in this assay, from the lowest: compound 2; then compounds 4 and 1 (each within the scatter of the next); then compound 3.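

In this assay, within the data shown here, hydrogen in place of allyl on an oxygen on an aromatic ring gives a 2.5-fold lower number from compound 3 to compound 4 (0.40 log units; beyond the scatter) in the first one-place comparison. The allyloxy group is thus not required for the inhibition seen with compound 3, and the change from allyloxy to hydroxy brings a modest gain rather than a loss. Even so, compound 4 at 22000 nM remains a weak inhibitor on this read-out, and no supporting measurement bears on what lies behind the step.

As far as these compounds go, whether the gain belongs to the free hydroxy or only to the loss of allyl stays open, and a methoxy or a longer chain such as butoxy on the same oxygen would help to separate the two. Also open, from the compounds shown here alone, is whether the same change carries over to the core of compound 1.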